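Sulfonamide swap on the path from compound 1 to compound 4

The source may hold more compounds than are shown below. What is called first, only, known or untested is meant among the compounds shown, and "the series" means these compounds.

Measured in a functional assay on MCF7 cells (Homo sapiens) for cytotoxicity, read by sulforhodamine B assay, with a stated time of 72 h; a lower number here means a stronger inhibitor, a higher number a weaker inhibitor:
Compound 1 (`Cc1cc(NS(=O)(=O)c2ccc(NCc3coc4ccccc4c3=O)cc2)no1`) gives (34500 nM)
Compound 2 (`O=C1/C(=C/c2coc3ccccc3c2=O)N=C(c2ccc(Cl)cc2)N1c1ccc(S(=O)(=O)Nc2ncccn2)cc1`) gives (> 100000 nM), a limit of the assay
Compound 3 (`O=C1N=C(Nc2ccc(S(=O)(=O)Nc3nccs3)cc2)S/C1=C/c1coc2ccccc2c1=O`) gives (> 100000 nM), a limit of the assay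

Compound 1 is the only one of the three with an actual number, at (34500 nM). The remaining results sit at one limit of the assay (the limit of > 100000 nM in this assay, at which 2 of the 3 values shown sit), so they give no size for any structural change.

Compound 4 (`O=c1c(CNc2ccc(S(=O)(=O)Nc3ncccn3)cc2)coc2ccccc12`) has not yet been measured. Its structure departs from compound 1 in one place (pyrimidin-2-yl in place of 5-methyl-1,2-oxazol-3-yl on a sulfonamide nitrogen), with pyrimidin-2-yl in place of 5-methyl-1,2-oxazol-3-yl on a sulfonamide nitrogen. Among the compounds with values here, no step between measured compounds is available as a guide to this exchange. The expectation therefore rests on compound 1 at (34500 nM), and in this assay it is for no change beyond the usual scatter, in either direction. The estimate amounts to a 1.2-fold higher number from compound 1 to compound 4 (0.06 log units; within the scatter) and is expected to stay small. A result reported only as a limit remains possible. The expected value for compound 4 is (40000 nM), with an estimated range from 15000 nM to 100000 nM (the range is an expectation too).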

Compound 4, half-maximal inhibitory concentration: > 100000 nM
Compound 4: a limit, no number (the forecaster's own chance of this, stated with the estimate: 25%); at least 2.5-fold (0.39 log units) between middle value and limit.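

In this assay, within the data shown here, the exchange of 5-methyl-1,2-oxazol-3-yl for pyrimidin-2-yl on a sulfonamide nitrogen gives the first step that can be read at a single place, and it amounts to an at least 2.8-fold higher number from compound 1 to compound 4 (0.46 log units; beyond the scatter). For compound 4, the value of > 100000 nM is a limit of the assay and not a number, so the step gives only a minimum size. The two groups have the same number of heavy atoms and hydrogen-bond acceptors, yet this position does not tolerate the exchange without a loss beyond the scatter, and compound 1 remains the only compound with an actual number: the limit of > 100000 nM in this assay, at which 3 of the 4 values shown sit.

As far as these compounds go, how far compound 4 really lies from compound 1 stays open, as does the question of whether any group at this position could bring the number below that of compound 1. The compounds shown also leave open how a plain phenyl ring or a simple methyl group on the same sulfonamide nitrogen would read in this assay.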